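The source may hold more compounds than are shown below. What is called first, only, known or untested is meant among the compounds shown, and "the series" means these compounds.

Measured so far:
Compound 1, `CN(C(=O)CC(CC(=O)NCCN1CCCC1)c1ccccc1)C1Cc2ccccc2C1`. In a functional assay on A549 cells (Homo sapiens) for inhibition (a lower number here means a stronger inhibitor, a higher number a weaker inhibitor), compound 1 gives only a limit, > 100000 nM.
Compound 2, `CN(C(=O)CC(CC(=O)NCCN1CCCC1)c1ccc(Cl)cc1)C1Cc2ccccc2C1`. In this assay compound 2 gives 56000 nM.
Compound 3, `CCNCCNC(=O)CC(CC(=O)N(CC)C1Cc2ccccc2C1)c1ccc(Cl)cc1`. In this assay compound 3 gives 19400 nM.

Compound 3 stands lowest of the two numbers, and its nearest neighbour is compound 2, beyond the scatter; the value of compound 1 is a limit of the assay (the limit of > 100000 nM in this assay, at which 1 of the 3 values shown sits). From compound 2 to compound 1 the structures differ in one place: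
hydrogen in place of chloro on an aromatic carbon
That change gave an at least 1.7-fold higher number from compound 2 to compound 1 (0.25 log units; that floor lies within the scatter). Compounds 2 and 3 differ in more than one place, so the difference between the two cores is not broken down here.

Compound 4, `CCNCCNC(=O)CC(CC(=O)N(CC)C1Cc2ccccc2C1)c1ccccc1`, is not yet measured. It differs from compound 3 as follows:
hydrogen in place of chloro on an aromatic carbon
The place lines agree word for word, so this is the same change as from compound 2 to compound 1. Resting on the step from compound 2 to compound 1 and on the value of compound 3, 19400 nM, compound 4 is therefore expected to give a higher number than compound 3. For compound 4 the expected step is a 2.6-fold higher number from compound 3 to compound 4 (0.41 log units; beyond the scatter). The estimate for compound 4 is 50000 nM. Its expected range runs from 20000 nM to 150000 nM.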

Compound 4, half-maximal inhibitory concentration: > 100000 nM
Compound 4 ended at the assay's limit (the forecaster's own chance of this, stated with the estimate: 25%); middle value at least 2.0-fold (0.30 log units) away from the limit.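

In this assay, the change from 4-chlorophenyl to phenyl gave an at least 5.1-fold higher number from compound 3 to compound 4 (0.71 log units; beyond the scatter). The change therefore gives a higher number on both cores, and on the core of compound 3 the step is beyond the scatter, whereas the floor of the step on the core of compound 1 lies within it. This shows that the direction held on both cores, but not that the size of the step carried over from one core to the other: the same change on two cores in this assay, an at least 1.7-fold higher number (0.25 log units; that floor lies within the scatter) from compound 2 to compound 1 and an at least 5.1-fold higher number (0.71 log units; beyond the scatter) from compound 3 to compound 4; the limit leaves it open whether they differ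

The compounds shown leave open the actual numbers of compound 1 and compound 4, each of which is a limit of the assay: the limit of > 100000 nM in this assay, at which 2 of the 4 values shown sit. They also leave open how other groups at the same place on the aromatic ring, such as fluoro, bromo or methoxy, would compare with chloro on either core.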